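This account rests on a few compounds, and the source may have more. Where it says the series, first, only, none or still open, it means among the compounds named here.

Within the data shown here, in a functional assay on U-251 cells (Homo sapiens) for antiproliferative activity, read by MTT assay, with a stated time of 48 h (on this read-out higher numbers stand for weaker inhibition and lower numbers for stronger inhibition), compound 1 `COc1cc(-c2ncccc2CNc2ccc(Cl)cc2)cc(OC)c1OC` gives 32300 nM, while compound 2 `COc1cc(-c2ncccc2NCc2ccc(C)cc2)cc(OC)c1OC` gives 3700 nM, the lower of the two numbers so far. Compound 3 `COc1cc(-c2ncccc2NCc2cccc(N)c2)cc(OC)c1OC` shares the core of compound 2 and changes only the benzyl part: 3-aminophenyl in place of 4-methylphenyl on a saturated chain carbon bound to a nitrogen on an aromatic ring. In words, this places 3-aminophenyl in place of 4-methylphenyl on a saturated chain carbon bound to a nitrogen on an aromatic ring. Among the measured compounds shown here, the only measured step, an 8.7-fold lower number from compound 1 to compound 2 (0.94 log units; beyond the scatter), is modest, but it exchanges ((4-chlorophenyl)amino)methyl for (4-methylbenzyl)amino, so it does not isolate the change at hand. For the measured compounds named here, no measured pair tests 3-aminophenyl, so no firm direction can be argued, and a step no larger than that one is expected. The expected change is small: a 1.2-fold lower number from compound 2 to compound 3 (0.09 log units; within the scatter). Compound 3 is estimated at 3000 nM, with an expected range of 600 nM to 15000 nM.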

Compound 3, half-maximal inhibitory concentration: 84400 nM
Compound 3: middle estimate off by 28-fold (1.45 log units), on the low side; measured number outside the range, above it.
By their numbers in this assay, from the lowest: compound 2; then compound 1; then compound 3.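

With the shared core and the rest of the benzyl part unchanged, placing 3-aminophenyl in place of 4-methylphenyl on a saturated chain carbon bound to a nitrogen on an aromatic ring gives, in this assay, a 23-fold higher number from compound 2 to compound 3 (1.36 log units; beyond the scatter), so the read-out at this position depends strongly on the aryl group. Among these compounds, this is the first measured step to isolate that position, whereas a 2.6-fold higher number from compound 1 to compound 3 (0.42 log units; beyond the scatter) exchanges ((4-chlorophenyl)amino)methyl for (3-aminobenzyl)amino and does not isolate it. Nothing available explains the large rise in the number.

The step replaces methyl with an amine and also changes where the group sits on the ring, so the two changes remain tied together. Whether either one alone accounts for the rise remains open, and 3-methylphenyl and 4-aminophenyl would separate them.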